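Changing the Side-Chain Ring of Compound 2

The compounds below may be only part of what the source reports. "The series", "measured", "known", "first", "only" and "open" are said of these compounds alone.

In an ADME assay on liver for metabolic stability, with Liver microsome (Homo sapiens) as the target, using microsomes and NADPH, with a stated time of 30 min, tested at 0.5 uM (a lower number here means slower removal, a higher number faster removal of the compound), compound 1 `O=c1[nH]ccn1CCOc1nn(-c2ccccc2F)c2ccc(F)cc12` gives 200 mL/min/kg and compound 2 `O=C1NCCN1CCOc1nn(-c2ccccc2F)c2ccc(F)cc12` gives 183 mL/min/kg, within the scatter of each other. Compound 3 `O=C1NCCN1CCOc1nn(-c2ccc(F)cc2)c2ccc(F)cc12` gives 66.7 mL/min/kg. Compound 2 thus stands with compound 1 at the high end of these numbers, above compound 3. Compound 4 `Fc1ccc2c(c1)c(OCCn1ccnc1)nn2-c1ccccc1F` keeps the core of compound 2 and alters the side chain: 1H-imidazol-1-yl in place of 2-oxoimidazolidin-1-yl on a saturated chain carbon, two bonds along the chain from an oxygen on an aromatic ring. The closest guide is a 1.1-fold lower number from compound 1 to compound 2 (0.04 log units; within the scatter), a ring exchange at the same place, which stays within the scatter. The other step, a 2.7-fold lower number from compound 2 to compound 3 (0.44 log units; beyond the scatter), is beyond the scatter but concerns the group on an aromatic nitrogen, so it bears little on this change. No step beyond the scatter is expected in this assay, and the expected step is a 1.1-fold lower number from compound 2 to compound 4 (0.03 log units; within the scatter). For compound 4 the estimate is 170 mL/min/kg, with an expected range of 90 mL/min/kg to 320 mL/min/kg.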

Compound 4, clearance: 150 mL/min/kg
Compound 4: the middle estimate sits 1.1-fold (0.05 log units) above what was measured, within the range that was stated.
By their numbers in this assay, from the lowest: compound 3; then compounds 4, 2 and 1 (each within the scatter of the next).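

Exchanging the side-chain ring in this assay gives a 1.2-fold lower number from compound 2 to compound 4 (0.09 log units; within the scatter), and taking the carbonyl oxygen out of the aromatic ring gives a 1.3-fold lower number from compound 1 to compound 4 (0.12 log units; within the scatter). On this core, then, a side-chain ring with no carbonyl gives a number that stays within the scatter of the two rings that carry one. Nothing measured here explains why these rings read alike.

Still open, as far as these compounds go, is whether an amine or a carboxylic acid in place of the ring, or a longer chain, would move the number. From the compounds shown here alone, it is also open whether 1H-imidazol-1-yl paired with the 4-fluorophenyl group of compound 3 would give a number as low as that compound's.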